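The source may hold more compounds than are shown below. What is called first, only, known or untested is meant among the compounds shown, and "the series" means these compounds.

In an ADME assay for metabolic stability, at pH 3.0 (a lower number here means that the compound disappears faster, a higher number that the compound lasts longer), compound 1 `COc1ccc2c(c1)COP(=O)(OC[C@@H]1C=C[C@H](n3cnc4c(N)ncnc43)O1)O2` gives 0.14 h, compound 2 `Nc1ncnc2c1ncn2[C@H]1C=C[C@@H](COP2(=O)OCc3ccccc3O2)O1` gives 0.14 h, and compound 3 `Cc1cc(C)c2c(c1)COP(=O)(OC[C@@H]1C=C[C@H](n3cnc4c(N)ncnc43)O1)O2` gives 0.14 h. Compound 3 therefore stands level with the other two at the digits available. Compound 4 `Cc1cccc2c1OP(=O)(OC[C@@H]1C=C[C@H](n3cnc4c(N)ncnc43)O1)OC2` has not yet been measured. It differs from compound 3 by one change: hydrogen in place of methyl on an aromatic carbon. In words, this is hydrogen in place of methyl on an aromatic carbon.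

Within the data shown here, only one measured step bears on this change, and it also puts hydrogen on an aromatic carbon, there in place of methoxy. That step shows no change at the digits printed from compound 1 to compound 2 (within the scatter). Among the measured compounds shown here, it involves a different departing group, so it is only an indirect guide, and no measured step removes a methyl group alone. On this evidence, no step beyond the scatter is expected in this assay, in either direction. The expected step is no change at the digits printed from compound 3 to compound 4 (within the scatter). For compound 4, the estimated half-life is 0.14 h, with an expected range from 0.1 h to 0.19 h.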

Compound 4, half-life in the ADME assay: 0.15 h
Estimate against measurement, compound 4: 1.1-fold (0.03 log units) below; the range from low to high includes it.
By their numbers in the ADME assay, from the lowest: compounds 1, 2, 3 and 4 (each within the scatter of the next).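

In the ADME assay, the loss of this methyl group can now be read directly, and the step shows a 1.1-fold higher number from compound 3 to compound 4 (0.03 log units; within the scatter), so hydrogen and methyl on this aromatic carbon, para to a fused ring, cannot be told apart by half-life. Methyl in place of hydrogen on an aromatic carbon gives the same picture, with a 1.1-fold higher number from compound 2 to compound 4 (0.03 log units; within the scatter). In a physicochemical assay for lipophilicity (on this read-out higher numbers stand for higher lipophilicity and lower numbers for lower lipophilicity), compound 3 gives 0.95 and compound 4 gives 0.63. The change is not silent everywhere, since lipophilicity shifts in the physicochemical assay while the half-life does not: the measured partition coefficient of compound 3, 0.95, and of compound 4, 0.63, a number 0.32 log units lower (beyond the scatter)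

The compounds shown carry only hydrogen, methyl and methoxy on this aromatic ring, so whether an amine or a carboxylic acid there would separate the compounds in the ADME assay remains open. As far as these compounds go, whether a change elsewhere in the shared core would do so in the ADME assay also remains open.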